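Swapping the aniline halogens: from compound 3 to compound 4

The source may hold more compounds than are shown below. What is called first, only, known or untested is meant among the compounds shown, and "the series" means these compounds.

Measured compounds:
compound 1, `C=CC(=O)Nc1cccc(NC(=O)CSc2nc(Nc3ccccc3F)c3ccccc3n2)c1` — in a functional assay on PC-3 cells (Homo sapiens) for inhibition, read by MTT assay, with a stated time of 72 h (on this read-out lower numbers stand for stronger inhibition and higher numbers for weaker inhibition), compound 1 gives 9340 nM
compound 2, `C=CC(=O)Nc1cccc(NC(=O)CSc2nc(Nc3ccc(Cl)c(Cl)c3)c3ccccc3n2)c1` — compound 2 gives 27600 nM
compound 3, `C=CC(=O)Nc1cccc(NC(=O)CSc2nc(Nc3ccc(F)c(Cl)c3)c3ccccc3n2)c1` — for compound 3 the result is only a limit, > 50000 nM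

All three share one core and differ only in the substituted phenyl ring attached to a nitrogen on an aromatic ring. Compound 3 sits at the weak end: its value is a limit of this assay rather than a number, since it falls at the limit of > 50000 nM in this assay, at which 1 of the 3 values shown sits. The two measured steps from compound 1 both went toward weaker inhibition, a 3.0-fold higher number from compound 1 to compound 2 (0.47 log units; beyond the scatter) and an at least 5.3-fold higher number from compound 1 to compound 3 (0.72 log units; beyond the scatter), while the exchange an at least 1.8-fold higher number from compound 2 to compound 3 (0.25 log units; that floor lies within the scatter) cannot be sized beyond its floor.

Compound 4, `C=CC(=O)Nc1cccc(NC(=O)CSc2nc(Nc3ccc(Cl)cc3Cl)c3ccccc3n2)c1`, is not yet measured. The change from compound 3 is 2,4-dichlorophenyl in place of 3-chloro-4-fluorophenyl on a nitrogen on an aromatic ring. Within the data shown here, none of the measured steps made this exact exchange; the nearest are the two dichloro and fluoro-chloro variants above, all weak. Compound 4 is therefore expected to remain weak, with an estimate of 30000 nM, in a range from 10000 nM to 100000 nM. The expected step is an at least 1.6-fold lower number from compound 3 to compound 4 (0.22 log units; that floor lies within the scatter), which may well stay within the scatter, and a limit-only result for compound 4 is a real possibility.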

Compound 4, half-maximal inhibitory concentration: 25700 nM
Compound 4: the middle estimate sits 1.2-fold (0.07 log units) above what was measured, within the range that was stated.
By their numbers in this assay, from the lowest: compound 1; then compounds 4 and 2 (each within the scatter of the next). At a limit, above all of these: compound 3.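

Moving a chlorine within the dichlorophenyl group makes no measurable difference here: a 1.1-fold lower number from compound 2 to compound 4 (0.03 log units; within the scatter), so 2,4-dichlorophenyl and 3,4-dichlorophenyl cannot be told apart on this read-out. The 2-fluorophenyl of compound 1 still stands apart from this new group, a 2.8-fold higher number from compound 1 to compound 4 (0.44 log units; beyond the scatter), so all three chlorine-bearing phenyl groups shown now give weaker inhibition than 2-fluorophenyl. The exchange of 3-chloro-4-fluorophenyl for 2,4-dichlorophenyl, an at least 1.9-fold lower number from compound 3 to compound 4 (0.28 log units; that floor lies within the scatter), can be read only as a floor and cannot be sized: the limit of > 50000 nM in this assay, at which 1 of the 4 values shown sits.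

The compounds shown leave open whether the stronger result of compound 1 follows from its fluorine or from carrying a single halogen. On these data alone, how a plain phenyl, or a phenyl bearing a methoxy group or an amine, would behave at this nitrogen also remains unknown.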